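Removing the Fluoro Group: What to Expect for Compound 4

The compounds below may be only part of what the source reports. "The series", "measured", "known", "first", "only" and "open" are said of these compounds alone.

Measured compounds:
compound 1 `CC(=NNC(=S)Nc1ccccc1F)c1ccccn1` — 5 nM
compound 2 `C/C(=N/NC(=S)Nc1ccc(Cl)cc1)c1ccccn1` — 1.7 nM
compound 3 `C/C(=N/NC(=S)Nc1ccccc1F)c1ccccn1` — 5 nM

In a functional assay on U-87MG ATCC cells (Homo sapiens) for cytotoxicity, read by MTT assay, with a stated time of 48 h (on this read-out lower numbers stand for stronger inhibition and higher numbers for weaker inhibition), compound 1 gives 5 nM, level with compound 3 and together the highest of the three numbers, while compound 2 gives 1.7 nM, a lower number. For the measured compounds named here, the only measured step between neighbours, no change at the digits printed from compound 1 to compound 3 (within the scatter), reflects the fact that one of compounds 1 and 3 is drawn with a defined configuration and the other without, at the place where they differ rather than any change of atoms, so it offers no guide to a real substitution. The new compound 4 `CC(=NNC(=S)Nc1ccccc1)c1ccccn1` differs from compound 1 as follows: hydrogen in place of fluoro on an aromatic carbon. Going by the values given here, no measured step bears on this change, so no shift beyond the scatter is expected, and the estimated step of no change at the digits printed from compound 1 to compound 4 (within the scatter) is taken as essentially flat. Compound 4 is therefore expected to give about 5 nM in this assay, within 1.5 nM to 17 nM.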

Compound 4, half-maximal inhibitory concentration: 1.4 nM
For compound 4 the middle estimate is 3.6-fold (0.55 log units) above the measured one; measured number outside the range, below it.
By their numbers in this assay, from the lowest: compounds 4 and 2 (each within the scatter of the next); then compounds 1 and 3 (each within the scatter of the next).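

Hydrogen in place of fluoro on an aromatic carbon, ortho to a large group, brings a real shift in this assay: a 3.6-fold lower number from compound 1 to compound 4 (0.55 log units; beyond the scatter). This place on the ring therefore responds to a change of atoms, which compounds 1 and 3 could not show, and the fluoro group is not needed for a low number here. Nothing available explains the shift.

On these data alone, whether a methoxy group or an amine at this same place would give a number closer to that of compound 1 or compound 4 remains open.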